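Swapping the dichlorophenyl thioether for a fluorophenoxy group

This account rests on a few compounds, and the source may have more. Where it says the series, first, only, none or still open, it means among the compounds named here.

Compound 3 `Nc1cc(N)c2nc(-c3ccccc3)c(Sc3ccc(Cl)c(Cl)c3)nc2c1` gives 31600 nM in a functional assay on RPMI8266 cells (Homo sapiens) for inhibition, read by sulforhodamine B assay, with a stated time of 48 h (a lower number here means a stronger inhibitor of growth, a higher number a weaker inhibitor of growth), the lowest of the two numbers reported. Its nearest neighbour is compound 2 `COc1ccc(Sc2nc3cc(N)cc(N)c3nc2-c2ccccc2)cc1`, which gives 85100 nM, and the step of a 2.7-fold lower number from compound 2 to compound 3 (0.43 log units; beyond the scatter) is beyond the scatter. Compound 1 `Nc1cc(N)c2nc(-c3ccccc3)c(Oc3ccc(Cl)c(Cl)c3)nc2c1` gives only a limit of < 100000 nM in this assay, so the step that the limit leaves unreadable from compound 1 to compound 3 has no readable size. Compound 4 `Nc1cc(N)c2nc(-c3ccccc3)c(Oc3ccc(F)cc3)nc2c1` differs from compound 3 by 4-fluorophenoxy in place of (3,4-dichlorophenyl)sulfanyl on an aromatic carbon. The change thus combines a sulfur-to-oxygen swap, whose effect is hidden because compound 1 sits at the limit (the limit of < 100000 nM in this assay, at which 1 of the 3 values shown sits), with a loss of the two chlorines that in the step of a 2.7-fold lower number from compound 2 to compound 3 (0.43 log units; beyond the scatter) cost a modest amount. Compound 4 is therefore expected to be weaker, estimated at 75000 nM with a range from 25000 nM to 200000 nM. That expected step of a 2.4-fold higher number from compound 3 to compound 4 (0.38 log units; beyond the scatter) would be beyond the scatter.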

Compound 4, concentration for total growth inhibition: 46800 nM
Estimate against measurement, compound 4: 1.6-fold (0.20 log units) above; low and high end bracket the measured number.
By their numbers in this assay, from the lowest: compounds 3, 4 and 2 (each within the scatter of the next, the first and the last beyond it).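

At this aromatic carbon, 4-fluorophenoxy in place of (3,4-dichlorophenyl)sulfanyl gives a 1.5-fold higher number from compound 3 to compound 4 (0.17 log units; within the scatter), and in place of (4-methoxyphenyl)sulfanyl it gives a 1.8-fold lower number from compound 2 to compound 4 (0.26 log units; within the scatter). Going by these compounds alone, compound 4 thus gives the first readable number in this assay for a group joined through oxygen at this position, and it lies within the scatter of both thioethers. The step from compound 1 to compound 4 cannot be read, like the other steps from compound 1: the limit of < 100000 nM in this assay, at which 1 of the 4 values shown sits.

Going by these compounds, the separate contributions of the oxygen link and the ring halogens remain open. So does the effect of an amine or a carboxylic acid on the phenoxy ring.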